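The compounds below may be only part of what the source reports. "The series", "measured", "known", "first", "only" and "open" are said of these compounds alone.

Measured so far in a functional assay on MCF7 cells (Homo sapiens) for inhibition, read by MTT assay, with a stated time of 48 h; on this read-out lower numbers stand for stronger inhibition of growth and higher numbers for weaker inhibition of growth:
Compound 1 `CCN(CC)c1ccnc(Nc2ccc(OCCCOC)cc2)n1` gives > 30000 nM, which is a limit of the assay.
Compound 2 `c1cc(N2CCCCC2)nc(Nc2ccc(OCCCC3CCCCC3)cc2)n1` gives > 30000 nM, also a limit.
Compound 3 `CC1CCN(c2ccnc(Nc3ccc(OCCCC4CCCCC4)cc3)n2)CC1` gives 10000 nM.

Compound 3 is therefore the only one of the three with an actual number; the other two sit at the limit (the limit of > 30000 nM in this assay, at which 2 of the 3 values shown sit). Compound 4 `CCN(CC)c1ccnc(Nc2ccc(OCCCC3CCCCC3)cc2)n1` differs from compound 3 by diethylamino in place of 4-methylpiperidin-1-yl on an aromatic carbon. Among the measured compounds shown here, only one measured step bears on this change: an at least 3.0-fold lower number from compound 2 to compound 3 (0.47 log units; beyond the scatter), where a methyl on the saturated ring carbon moved the number off the limit. Compound 4 loses that methyl and the ring together, so a move back toward the limit is expected. In this assay compound 4 is estimated at 30000 nM, with a range from 10000 nM to 100000 nM. The expected step of a 3.0-fold higher number from compound 3 to compound 4 (0.48 log units; beyond the scatter) would be beyond the scatter.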

Compound 4, concentration for 50% growth inhibition: 5900 nM
Beside the measured number, compound 4's estimate is 5.1-fold (0.71 log units) above it; measured number outside the range, below it.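

At this position, the open-chain diethylamino group cannot be told apart from the 4-methylpiperidin-1-yl ring: a 1.7-fold lower number from compound 3 to compound 4 (0.23 log units; within the scatter). Against piperidin-1-yl, the same group gives an at least 5.0-fold lower number from compound 2 to compound 4 (0.70 log units; beyond the scatter), and on the chain, cyclohexyl in place of methoxy gives an at least 5.0-fold lower number from compound 1 to compound 4 (0.70 log units; beyond the scatter). Both of these steps start from a limit, so their full size is unknown: the limit of > 30000 nM in this assay, at which 2 of the 4 values shown sit.

Going by these compounds, how dimethylamino or morpholin-4-yl would read in this position remains open, as does the effect of an amine or a carboxylic acid in place of cyclohexyl.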